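The source may hold more compounds than are shown below. What is called first, only, known or untested is meant among the compounds shown, and "the series" means these compounds.

Compound 2 `COc1ccc2c(c1)C(=O)[C@H](O)[C@@H](c1cccc(O)c1O)O2` is one of two compounds already tested in a functional assay on RAW264.7 cells (Rattus norvegicus) for inhibition, with RAW264.7 (Mus musculus) as the target, read by Griess assay, with stated times of 2 h and 16 h; a higher number here means a weaker inhibitor, a lower number a stronger inhibitor. In this assay compound 2 gives > 100000 nM, which is a limit of the assay and not a number. Among the values shown, compound 2 thus stands at the limit of > 100000 nM in this assay, at which 1 of the 2 values shown sits. The other tested compound is compound 1 `O=C1c2c(O)cccc2O[C@H](c2cccc(O)c2O)[C@H]1O`, which in this assay gives 77700 nM. Compound 3 `O=C1c2cc(O)ccc2O[C@H](c2cccc(O)c2O)[C@H]1O` has not yet been measured. The change from compound 2 to compound 3 is hydrogen in place of methyl on an oxygen on an aromatic ring. No step between two measured compounds is shown here, so nothing measured tells how large such a change should be. Compound 1 gives 77700 nM, a number at the weak end of the scale. The expected step is an at least 1.1-fold lower number from compound 2 to compound 3 (0.04 log units; that floor lies within the scatter), small or none beyond the usual scatter, in either direction. Compound 3 is therefore expected to give about 90000 nM in this assay, with a range from 30000 nM to 300000 nM, and a fair chance that only a limit is reported.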

Compound 3, half-maximal inhibitory concentration: > 100000 nM
Compound 3 was reported as a limit; the forecaster's own chance of this, stated with the estimate: 50%; middle value at least 1.1-fold (0.04 log units) away from the limit.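

Compound 2 and compound 3 are both reported only as limits of the assay, not as numbers, so no step from methoxy to hydroxy can be read between them: the limit of > 100000 nM in this assay, at which 2 of the 3 values shown sit.

As far as these compounds go, whether this change alters inhibition in this assay at all, and in which direction or by how much, stays open.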